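The source may hold more compounds than are shown below. What is called first, only, known or untested is meant among the compounds shown, and "the series" means these compounds.

Measured in a functional assay on MCF7 cells (Homo sapiens) for inhibition, with a stated time of 48 h; on this read-out higher numbers stand for weaker inhibition and lower numbers for stronger inhibition:
- Compound 1 `COc1cc(Sc2c[nH]c3ccc(I)cc23)cc(OC)c1OC`: 68 nM
- Compound 2 `COc1cc(Sc2c[nH]c3ccc([N+](=O)[O-])cc23)cc(OC)c1OC`: 560 nM

Among the measured compounds shown here, compound 2 holds the higher number of the pair, so it is the weaker inhibitor, with compound 1 as its only neighbour. Compound 3 `CCOc1ccc2[nH]cc(Sc3cc(OC)c(OC)c(OC)c3)c2c1` differs from compound 2 by ethoxy in place of nitro on an aromatic carbon. For the measured compounds named here, one measured step bears on this change: an 8.2-fold higher number from compound 1 to compound 2 (0.92 log units; beyond the scatter), where nitro replaced iodo. Going by the values given here, no measured compound carries ethoxy, so the guide is thin. On that step alone, a modest move to a lower number is expected in this assay once nitro leaves. The estimated change is a 3.1-fold lower number from compound 2 to compound 3 (0.49 log units; beyond the scatter). For compound 3 the expected value is 180 nM, with an estimated range of 50 nM to 600 nM.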

Compound 3, half-maximal inhibitory concentration: 16 nM
Beside the measured number, compound 3's estimate is 11-fold (1.05 log units) above it; the measured number lies below the stated range.
By their numbers in this assay, from the lowest: compound 3; then compound 1; then compound 2.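

In this assay, ethoxy on this aromatic carbon gives a 35-fold lower number from compound 2 to compound 3 (1.54 log units; beyond the scatter), and it also improves on iodo, with a 4.3-fold lower number from compound 1 to compound 3 (0.63 log units; beyond the scatter). The earlier pair showed only that iodo gave a lower number than nitro; the lowest number at this position now belongs to neither group, and the three groups span a wider range.

Nothing available explains this order. Going by these compounds, whether methoxy, a longer chain such as propoxy, or an amine on this carbon would extend the trend remains open.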